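Replacing an Ether With a Phenyl on the Amide Ring

The compounds below may be only part of what the source reports. "The series", "measured", "known", "first", "only" and "open" are said of these compounds alone.

Of the compounds shown here, two with one shared core have been measured. Compound 1, `O=C(CN1CCC(c2cccc[n+]2[O-])CC1)Nc1cccc(F)c1`, gives 160 nM in a functional assay on HEK293 cells for agonist activity at D(4) dopamine receptor (Homo sapiens), read by FLIPR; a higher number here means that more compound is needed for the effect, a lower number that less compound is needed. Compound 2, `CC(C)Oc1cccc(NC(=O)CN2CCC(c3cccc[n+]3[O-])CC2)c1`, gives 555 nM in this assay. They differ in one place, and the step is a 3.5-fold higher number from compound 1 to compound 2 (0.54 log units; beyond the scatter). Among the compounds with values here, compound 2 therefore stands with the higher of the two numbers, its only neighbour being compound 1, which sits lower by that modest step.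

Compound 3, `O=C(CN1CCC(c2cccc[n+]2[O-])CC1)Nc1cccc(-c2ccccc2)c1`, differs from compound 2 in one place as well: phenyl in place of isopropoxy on an aromatic carbon. Within the data shown here, the only measured step that bears on this change is the one from compound 1 to compound 2, where exchanging one group for another at the same aromatic carbon raised the number modestly. Phenyl is a third group at this position, and the data offer no second example to show whether the rise continues. The expectation is a further modest rise in this assay, or a step no larger than the scatter, rather than a fall. The expected step is a 1.6-fold higher number from compound 2 to compound 3 (0.21 log units; within the scatter). Compound 3 is thus estimated at 900 nM, with a range from 250 nM to 3000 nM.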

Compound 3, half-maximal effective concentration: 360 nM
Estimate against measurement, compound 3: 2.5-fold (0.40 log units) above; the range from low to high includes it.
By their numbers in this assay, from the lowest: compound 1; then compounds 3 and 2 (each within the scatter of the next).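

In this assay, the isopropoxy group can give way to phenyl with a 1.5-fold lower number from compound 2 to compound 3 (0.19 log units; within the scatter), so this aromatic carbon holds a six-membered aromatic ring of carbon only and gives a number that cannot be told apart from that of the isopropoxy compound, even though the one hydrogen-bond acceptor of isopropoxy is gone. Set against the fluoro compound, the same ring gives a 2.3-fold higher number from compound 1 to compound 3 (0.35 log units; beyond the scatter), so compound 1 keeps the lowest number of the three, with steps beyond the scatter to both compound 2 and compound 3, while the two groups that replace fluoro, one with oxygen and no ring and the other a ring with no oxygen, land close together. Nothing measured alongside these values explains why fluoro gives the lowest number or why the other two groups give such similar ones.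

Three groups on one carbon are too few to show what sets the number at this position. From the compounds shown here alone, whether a methoxy group, an amine or a carboxylic acid here would sit nearer compound 1 or nearer compound 2 and compound 3 remains open, as does whether a longer chain would continue the same picture.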